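Substituent on the shared core: from compound 3 to compound 4

This account rests on a few compounds, and the source may have more. Where it says the series, first, only, none or still open, it means among the compounds named here.

Of the compounds shown here, three sharing one core have been measured. Compound 1 `O=C(CCCCCCc1ccccc1)c1nc(Br)co1` gives 3 nM in an assay on isolated protein for inhibition of Fatty-acid amide hydrolase 1 (Rattus norvegicus); on this read-out higher numbers stand for weaker inhibition and lower numbers for stronger inhibition; compound 2 `O=C(CCCCCCc1ccccc1)c1nc(C(=O)C(F)(F)F)co1` gives 470 nM; compound 3 `O=C(CCCCCCc1ccccc1)c1nc(-c2cccnc2)co1` gives 18 nM. Compound 3 stands second highest of the three numbers: its nearest neighbour is compound 1, with a 6.0-fold higher number from compound 1 to compound 3 (0.78 log units; beyond the scatter), and its furthest is compound 2, with a 26-fold lower number from compound 2 to compound 3 (1.42 log units; beyond the scatter). The group on the aromatic carbon of the five-membered ring thus sets the number across a wide span, as a 160-fold higher number from compound 1 to compound 2 (2.19 log units; beyond the scatter) also shows.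

Compound 4 `O=C(CCCCCCc1ccccc1)c1nc(-c2ccccc2)co1` is not yet measured. It differs from compound 3 in one place: phenyl in place of pyridin-3-yl on an aromatic carbon. Within the data shown here, no measured step exchanges one six-membered aromatic ring for another; all three known steps involve bromo or (trifluoromethyl)carbonyl and so bear only indirectly, by showing that this position tolerates wide differences without a clear rule. The exchange of pyridin-3-yl for phenyl keeps the ring count and removes the single hydrogen-bond acceptor; a modest move toward a higher number is expected, amounting to a 2.2-fold higher number from compound 3 to compound 4 (0.35 log units; beyond the scatter). Compound 4 is therefore estimated at 40 nM, with a range from 10 nM to 150 nM.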

Compound 4, inhibition constant: 65 nM
Compound 4: middle estimate off by 1.6-fold (0.21 log units), on the low side; measured number inside the range.
By their numbers in this assay, from the lowest: compound 1; then compound 3; then compound 4; then compound 2.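

Two six-membered aromatic rings can now be compared directly at this carbon in this assay, and a 3.6-fold higher number from compound 3 to compound 4 (0.56 log units; beyond the scatter) shows that going from a ring with 1 hetero atom to a ring of carbon only, with 6 heavy atoms on both sides, moves the number beyond the scatter. Phenyl sits well away from both non-ring groups, with a 22-fold higher number from compound 1 to compound 4 (1.34 log units; beyond the scatter) on one side and a 7.2-fold lower number from compound 2 to compound 4 (0.86 log units; beyond the scatter) on the other, so the four groups now run in the order bromo, pyridin-3-yl, phenyl, (trifluoromethyl)carbonyl. Neither aromatic ring matches bromo, but pyridin-3-yl stays closer to it than phenyl does, so the ring nitrogen recovers part of the rise in the number that phenyl shows.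

Going by these compounds, whether that recovery depends on where the nitrogen sits in the ring remains open, as pyridin-2-yl and pyridin-4-yl groups would test this, and so does the effect of adding an amine or a carboxylic acid to the phenyl ring. Nothing at hand accounts for the difference between the two rings.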